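From indolyl to indolylmethyl on the shared core

The compounds below may be only part of what the source reports. "The series", "measured", "known", "first", "only" and "open" are said of these compounds alone.

Measured in a functional assay on K562 cells (Homo sapiens) for inhibition, read by trypan blue exclusion, with a stated time of 72 h; on this read-out higher numbers stand for weaker inhibition and lower numbers for stronger inhibition:
- Compound 1 `Cn1c(=O)c(S(=O)(=O)c2ccc(F)cc2F)cc2cnc(Nc3cnc4[nH]ccc4c3)nc21`: 750 nM
- Compound 2 `Cn1c(=O)c(S(=O)(=O)c2ccc(F)cc2F)cc2cnc(Nc3ccc4cc[nH]c4c3)nc21`: 5000 nM

Of these two compounds, compound 2 carries the higher number, 5000 nM, and so is the weaker inhibitor in this assay. Compound 3 `Cn1c(=O)c(S(=O)(=O)c2ccc(F)cc2F)cc2cnc(NCc3ccc4[nH]ccc4c3)nc21` has not yet been measured. It differs from compound 2 by (1H-indol-5-yl)methyl in place of 1H-indol-6-yl on a nitrogen on an aromatic ring, which places (1H-indol-5-yl)methyl where 1H-indol-6-yl stood, on a nitrogen on an aromatic ring. Within the data shown here, only one measured step bears on this change: a 6.7-fold higher number from compound 1 to compound 2 (0.82 log units; beyond the scatter). That step replaced the group on the same nitrogen and moved the number beyond the scatter, so a change here can matter. It did not test (1H-indol-5-yl)methyl, however, and therefore suggests a possible size but no firm direction. Among the measured compounds shown here, no measured compound carries this group, so a step no larger than that one is expected, with a slight lean towards a higher number. The expected step is a 1.2-fold higher number from compound 2 to compound 3 (0.08 log units; within the scatter). Compound 3 is estimated at 6000 nM, with an expected range from 1500 nM to 25000 nM.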

Compound 3, half-maximal inhibitory concentration: 75000 nM
Beside the measured number, compound 3's estimate is 13-fold (1.10 log units) below it; measured number outside the range, above it.
By their numbers in this assay, from the lowest: compound 1; then compound 2; then compound 3.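

In this assay, the change to (1H-indol-5-yl)methyl on this nitrogen gives a 15-fold higher number from compound 2 to compound 3 (1.18 log units; beyond the scatter), a large step where the earlier change of group at the same place was only modest, so this position tolerates some replacements far less well than the first pair suggested. Measured against the best of the set, the group gives a 100-fold higher number from compound 1 to compound 3 (2.00 log units; beyond the scatter), which makes compound 3 the weakest of the three compounds and shows that the number at this nitrogen can span a wide range on the shared core. No evidence is available to explain why this change costs so much.

The step from compound 2 to compound 3 alters two things at once, adding a methyl link and moving from the 6-yl to the 5-yl attachment of the indole, so the compounds shown cannot say how much of the loss belongs to each. A 1H-indol-5-yl group on this nitrogen or a (1H-indol-6-yl)methyl group would separate the two, and a plain benzyl group would ask whether the indole matters at all once the methyl link is present.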